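Amide side-chain variation on the shared core: cytotoxicity notes

The source may report more compounds than this note shows. Statements on the series, on what has been measured and on what is new or still open speak of the compounds shown alone.

Measured compounds:
compound 1 `C[C@H]1O[C@@H](n2ccc(NC(=O)CC(C)(C)O)nc2=O)CC[C@@H]1O` — in a functional assay on HCT-116 cells (Homo sapiens) for cytotoxicity, read by sulforhodamine B assay, with a stated time of 24 h (a higher number here means a weaker inhibitor, a lower number a stronger inhibitor), compound 1 gives only the assay limit, > 20000 nM
compound 2 `CC(C)=CCC(=O)Nc1ccn([C@H]2CC[C@H](O)[C@@H](C)O2)c(=O)n1` — in this assay compound 2 gives only the assay limit, > 20000 nM
compound 3 `CC(C)/C=C/C(=O)Nc1ccn([C@H]2CC[C@H](O)[C@@H](C)O2)c(=O)n1` — in this assay compound 3 gives only the assay limit, > 20000 nM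

Compound 3 stands at the limit of this assay and not at a number; every value shown sits there, as the limit of > 20000 nM in this assay, at which 3 of the 3 values shown sit, records. The steps between the measured compounds are therefore without a readable size: a step that the two limits leave unreadable from compound 1 to compound 2; a step that the two limits leave unreadable from compound 1 to compound 3; a step that the two limits leave unreadable from compound 2 to compound 3.

Compound 4 `CC(C)C(=O)Nc1ccn([C@H]2CC[C@H](O)[C@@H](C)O2)c(=O)n1` differs from compound 3 in one place: isopropyl in place of 3-methylbut-1-en-1-yl on a carbonyl carbon. Variation of the group on the carbonyl carbon across compounds 1, 2 and 3 has not moved any of them off the limit, so the measured steps give no direction and no size for this change. The expected step from compound 3 to compound 4 in this assay is a step that the limit leaves unreadable from compound 3 to compound 4, with a high chance that compound 4 again returns only a limit. Compound 4 is estimated at 40000 nM in this assay, within 12000 nM to 150000 nM.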

Compound 4, half-maximal inhibitory concentration: > 20000 nM
Compound 4 ended at the assay's limit; the forecaster's own chance of this, stated with the estimate: 85%; the middle value does not contradict the limit.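

Compound 4 returns only a limit in this assay as do compound 1, compound 2 and compound 3, so no new step among these compounds can be read. The compounds shown leave open whether any group on the carbonyl carbon gives a value off this limit.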